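From 4-fluorophenyl to phenyl at the assay limit

A few compounds are considered here, and "the series" means these few. Any claim that something is new, unique, unknown or untested is made for them only; others in the source may bear on it.

Compound 1 `COc1cc(-c2ncnn2-c2cccc(F)c2)cc(OC)c1OC` and compound 2 `COc1cc(-c2ncnn2-c2ccc(F)cc2)cc(OC)c1OC` share a core. In a functional assay on Jurkat cells (Homo sapiens) for antiproliferative activity, read by MTT assay, with a stated time of 72 h (a lower number here means a stronger inhibitor, a higher number a weaker inhibitor), compound 1 gives > 10000 nM, which is a limit. Compound 2 gives > 10000 nM, also a limit. Compound 2 therefore stands at the limit of > 10000 nM in this assay, at which 2 of the 2 values shown sit. Compound 3 `COc1cc(-c2ncnn2-c2ccccc2)cc(OC)c1OC` carries hydrogen in place of fluoro on an aromatic carbon, hydrogen in place of fluoro on an aromatic carbon. Within the data shown here, the only measured step is a step that the two limits leave unreadable from compound 1 to compound 2, so it offers no size to carry over, and in this assay no step beyond the scatter and no direction can be expected. The estimated step that the limit leaves unreadable from compound 2 to compound 3 is therefore only tentative. Compound 3 is expected at 15000 nM, within a range from 4000 nM to 40000 nM.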

Compound 3, half-maximal inhibitory concentration: > 10000 nM
Compound 3: no number, only a limit; the forecaster's own chance of this, stated with the estimate: 75%; the middle value does not contradict the limit.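

Compound 3 gives > 10000 nM in this assay, which is a limit. No step among compound 1, compound 2 and compound 3 can therefore be read: the limit of > 10000 nM in this assay, at which 3 of the 3 values shown sit.

These compounds leave open whether swapping fluoro for hydrogen, or moving the fluoro, changes the activity at all.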